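The source may report more compounds than this note shows. Statements on the series, on what has been measured and on what is new or still open speak of the compounds shown alone.

Measured in an ADME assay for permeability, using PAMPA, with a stated time of 4 h, at pH 5.5; a lower number here means that the compound crosses the layer more slowly, a higher number that the compound crosses the layer faster:
- compound 1 `NCCCCN(C[C@H]1Cc2cccnc2CN1)[C@H]1CCCc2cccnc21`: 2 nm/s
- compound 2 `CCN(CC)CCCCN(C[C@H]1Cc2ncccc2CN1)[C@H]1CCCc2cccnc21`: 3 nm/s
- compound 3 `CN(CCCCN(C[C@H]1Cc2ncccc2CN1)[C@H]1CCCc2cccnc21)C1CCC(F)(F)CC1`: 15 nm/s

In this assay, compound 3 at 15 nm/s has the highest of the three numbers, and both compound 2 and compound 1 lie lower by more than the scatter.

The next compound is compound 4 `c1cnc2c(c1)CN[C@@H](CN(CCCCN(C1COC1)C1COC1)[C@H]1CCCc3cccnc31)C2`. The change is a group of 9 heavy atoms (6 carbon, 1 nitrogen, 2 oxygen; 2 four-membered non-aromatic rings with 1 hetero atom each) in place of a group of 10 heavy atoms (7 carbon, 1 nitrogen, 2 fluorine; one six-membered non-aromatic ring of carbon only), on a saturated chain carbon, four bonds along the chain from an amine nitrogen: a group with 2 four-membered non-aromatic rings with 1 hetero atom each takes the place of the group with one six-membered non-aromatic ring of carbon only.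

Going by the values given here, one measured step bears on this place, a 5.0-fold higher number from compound 2 to compound 3 (0.70 log units; beyond the scatter), which is modest but beyond the scatter. The group that leaves now is the one that entered in that step, but the incoming group is not the small open-chain one of compound 2. It has a similar heavy-atom count to the group it replaces and more hydrogen-bond acceptors. Among the compounds with values here, no measured compound carries the incoming group, so the direction rests on little, and only a slight fall is expected, not a return to the level of compound 2.

The expected change is a 1.5-fold lower number from compound 3 to compound 4 (0.18 log units; within the scatter), which would stay within the scatter.

For compound 4 the estimated value is 10 nm/s, with an expected range of 3 nm/s to 40 nm/s.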

Compound 4, apparent permeability: 62 nm/s
Compound 4: middle estimate off by 6.2-fold (0.79 log units), on the low side; measured number above the stated range.
By their numbers in this assay, from the lowest: compounds 1 and 2 (each within the scatter of the next); then compound 3; then compound 4.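

In this assay, the group with 2 four-membered non-aromatic rings with 1 hetero atom each, taking the place of the group with one six-membered non-aromatic ring of carbon only on a saturated chain carbon, four bonds along the chain from an amine nitrogen, gives a 4.1-fold higher number from compound 3 to compound 4 (0.62 log units; beyond the scatter), so the number at this place can rise well past the level of compound 3 even though the heavy-atom count drops and the hydrogen-bond acceptor count rises. Going by these compounds alone, measured from the open-chain group of 5 heavy atoms, the same exchange gives a 21-fold higher number from compound 2 to compound 4 (1.32 log units; beyond the scatter), the only step at this place that counts as large and one that makes the ringed groups stand clearly apart from the open-chain one. No measurement shown here accounts for the rise.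

From the compounds shown here alone, whether the two four-membered rings must both be present remains open, and an amine carrying only one of them, or a morpholine at the same place, would separate the effect of ring count from that of the ring oxygen atoms. Going by these compounds, whether the same order holds in this assay on a longer chain also remains open.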